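This account rests on a few compounds, and the source may have more. Where it says the series, first, only, none or still open, it means among the compounds named here.

Compound 1 `Cc1ccc(C(=O)Nc2cccc(-c3oc4cc(-c5ccc(F)cc5)ccc4c(=O)c3O)c2)cc1`: in a functional assay on HCC1937 cells (Homo sapiens) for antiproliferative activity, read by CCK-8 assay, with a stated time of 72 h (a higher number here means a weaker inhibitor, a lower number a stronger inhibitor), compound 1 gives 7110 nM.
Compound 2 `O=C(Nc1cccc(-c2oc3cc(-c4ccc(F)cc4)ccc3c(=O)c2O)c1)c1ccc(C(F)(F)F)cc1`: in this assay compound 2 gives 7350 nM.
Compound 3 `Cc1cccc(C(=O)Nc2cccc(-c3oc4cc(-c5ccc(F)cc5)ccc4c(=O)c3O)c2)c1`: in this assay compound 3 gives 8030 nM.

Compound 3 cannot be separated from its two neighbours: the steps of a 1.1-fold higher number from compound 1 to compound 3 (0.05 log units; within the scatter) and a 1.1-fold higher number from compound 2 to compound 3 (0.04 log units; within the scatter) both lie within the scatter, as does a 1.0-fold higher number from compound 1 to compound 2 (0.01 log units; within the scatter). All three compounds share the same core and differ only in the substituent pattern of the ring attached to the amide carbonyl.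

Compound 4 `Cc1cc(C(=O)Nc2cccc(-c3oc4cc(-c5ccc(F)cc5)ccc4c(=O)c3O)c2)ccc1F` carries the change (fluoro in place of hydrogen on an aromatic carbon). Among the measured compounds shown here, no measured step exchanges hydrogen for fluoro, so nothing bears on it directly. The closest precedents are the three changes on the same amide-linked ring, a 1.0-fold higher number from compound 1 to compound 2 (0.01 log units; within the scatter), a 1.1-fold higher number from compound 1 to compound 3 (0.05 log units; within the scatter) and a 1.1-fold higher number from compound 2 to compound 3 (0.04 log units; within the scatter), every one of them within the scatter; on that basis no step beyond the scatter is expected in this assay, in either direction, and compound 4 is expected to give a 1.0-fold lower number from compound 3 to compound 4 (0.01 log units; within the scatter). Compound 4 is therefore estimated at 7800 nM, with a range from 3900 nM to 15600 nM.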

Compound 4, half-maximal inhibitory concentration: 5420 nM
Beside the measured number, compound 4's estimate is 1.4-fold (0.16 log units) above it; measured number inside the range.
By their numbers in this assay, from the lowest: compounds 4, 1, 2 and 3 (each within the scatter of the next).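

In this assay, fluoro on an aromatic carbon, ortho to a methyl group and para to a large group, gives a 1.5-fold lower number from compound 3 to compound 4 (0.17 log units; within the scatter), so this first exchange of hydrogen for fluoro on the ring yields no step beyond the scatter. The 4-fluoro-3-methylphenyl group also cannot be separated from the other two groups on the carbonyl carbon, with a 1.4-fold lower number from compound 2 to compound 4 (0.13 log units; within the scatter) and a 1.3-fold lower number from compound 1 to compound 4 (0.12 log units; within the scatter). All four substituent patterns on this ring now lie within the scatter of one another, and nothing available accounts for the small steps among them.

Going by these compounds, whether an amine, a carboxylic acid or a longer chain on this same carbon would move the number beyond the scatter remains open. Also open, on these data alone, is whether fluoro would behave the same way without the methyl group on the ring.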